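Methyl in place of methoxycarbonyl on a weakly cytotoxic sulfonamide

The source may hold more compounds than are shown below. What is called first, only, known or untested is meant among the compounds shown, and "the series" means these compounds.

The study looks at two measured compounds and one that is yet to be tested. Compound 1 `COC(=O)c1cc2c(cc1Cl)SC(N(N(C)C)S(=O)(=O)c1ccc(Cl)cc1)=NS2(=O)=O` and compound 2 `CCOC(=O)c1cc2c(cc1Cl)SC(N(c1ccc(F)cc1)S(=O)(=O)c1ccc(OC)cc1)=NS2(=O)=O` share a fused core and were both examined in a functional assay on RT-4 cells (Homo sapiens) for cytotoxicity, with a stated time of 96 h; on this read-out higher numbers stand for weaker inhibition of growth and lower numbers for stronger inhibition of growth. In this assay compound 1 gives 18500 nM, and in this assay compound 2 gives 19000 nM; the two numbers lie within the scatter of each other, so neither stands apart.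

Compound 3 `Cc1cc2c(cc1Cl)SC(N(N(C)C)S(=O)(=O)c1ccc(Cl)cc1)=NS2(=O)=O` is not yet measured. It differs from compound 1 in one place: methyl in place of methoxycarbonyl on an aromatic carbon. Among the measured compounds shown here, no step between measured compounds touches this position, so there is no direct precedent within the set for what the exchange does in this assay.

Given that compound 1 gives 18500 nM in this assay, the expectation for compound 3 is a step of a 1.4-fold higher number from compound 1 to compound 3 (0.13 log units; within the scatter), in the direction of weaker inhibition of growth but not clearly beyond the scatter. Compound 3 is therefore estimated at 25000 nM in this assay, with a range from 8000 nM to 80000 nM.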

Compound 3, concentration for 50% growth inhibition: > 20000 nM
Compound 3: no number, only a limit; the forecaster's own chance of this, stated with the estimate: 25%; the middle value does not contradict the limit.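

In this assay compound 3 has a limit and not a number: > 20000 nM. The exchange of methoxycarbonyl for methyl on this aromatic carbon, ortho to a chloro group, gives an at least 1.0-fold higher number from compound 1 to compound 3 (0.03 log units; that floor lies within the scatter), so the change can be read only as a floor, and that floor does not separate the pair. This is the first view of the position, and it shows that replacing methoxycarbonyl with methyl brings no stronger inhibition of growth into view in this assay, while how far compound 3 lies past its limit cannot be told: the limit of > 20000 nM in this assay, at which 1 of the 3 values shown sits.

As far as these compounds go, whether a carboxylic acid, an amine or a longer chain on this aromatic carbon of the core of compound 1 would give a clearly different value in this assay remains open. Also open, from the compounds shown here alone, is whether the methyl leaves growth inhibition essentially unchanged or weakens it clearly, since a limit cannot settle that, and compound 2 differs from compound 1 in more than one place and offers no reading of this position.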